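The source may hold more compounds than are shown below. What is called first, only, known or untested is meant among the compounds shown, and "the series" means these compounds.

Series notes: in an in vitro ADME assay on microsomes from liver (Simiiformes) (a lower number here means that the compound disappears faster, a higher number that the compound lasts longer), compound 1 `CCc1cc(CCCOc2c(C)cc(-c3noc(C)n3)cc2C)on1` gives 0.183 h, the lower of the two numbers so far, and compound 2 `CCc1cc(CCCOc2c(C)cc(-c3noc(C4CC4)n3)cc2C)on1` gives 0.9 h. Among the compounds with values here, the only measured step, a 4.9-fold higher number from compound 1 to compound 2 (0.69 log units; beyond the scatter), is modest and beyond the scatter. It is cyclopropyl in place of methyl on an aromatic carbon, which is not the place changed next. Compound 3 `COCc1cc(CCCOc2c(C)cc(-c3noc(C)n3)cc2C)on1` differs from compound 1 by methoxy in place of methyl on a saturated chain carbon bound to an aromatic carbon, which also reads as ethyl to methoxymethyl. Within the data shown here, no measured step covers this change, so the one step available shows only how far a single change has moved this assay in this pair and gives no direction here. A small step, probably within the scatter, is expected, and the estimate is a 1.2-fold higher number from compound 1 to compound 3 (0.08 log units; within the scatter). For compound 3 the expected value is 0.22 h, with an estimated range from 0.09 h to 0.55 h.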

Compound 3, half-life: 0.5 h
Beside the measured number, compound 3's estimate is 2.3-fold (0.36 log units) below it, within the range that was stated.
By their numbers in this assay, from the lowest: compound 1; then compounds 3 and 2 (each within the scatter of the next).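

In this assay, the change from ethyl to methoxymethyl, which puts methoxy in place of methyl on a saturated chain carbon bound to an aromatic carbon, gives a 2.7-fold higher number from compound 1 to compound 3 (0.44 log units; beyond the scatter). This place on the core of compound 1 therefore also responds to a single change, so the response is no longer confined to the cyclopropyl in place of methyl seen in a 4.9-fold higher number from compound 1 to compound 2 (0.69 log units; beyond the scatter). Nothing at hand explains the step at this place.

The compounds shown leave open whether this step follows the entering oxygen or the extra heavy atom, a question that propyl in place of methoxymethyl on the same ring would address. They also leave open whether methoxymethyl and cyclopropyl, carried together in one compound, would add up in this assay.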